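A few compounds are considered here, and "the series" means these few. Any claim that something is new, unique, unknown or untested is made for them only; others in the source may bear on it.

Compound 1 `COc1ccc(CNc2cc(OC)c(OC)c(OC)c2)cc1[N+](=O)[O-]`: 18200 nM
Compound 2 `COc1ccc(CNc2cc(OC)c(OC)c(OC)c2)cc1Cl`: 41700 nM

In a functional assay on HCT-116 cells (Homo sapiens) for inhibition, read by MTT assay, with a stated time of 48 h (a lower number here means a stronger inhibitor, a higher number a weaker inhibitor), compound 2 at 41700 nM holds the higher of the two numbers, so it is the weaker inhibitor of the pair. Next in the series is compound 3 `COc1ccc(CNc2cc(OC)c(OC)c(OC)c2)cc1Br`, with this change from compound 2: bromo in place of chloro on an aromatic carbon. In words, bromo replaces chloro on an aromatic carbon, ortho to a methoxy group.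

Going by the values given here, only one measured step bears on this: a 2.3-fold higher number from compound 1 to compound 2 (0.36 log units; beyond the scatter). Among the compounds with values here, that modest step is chloro in place of nitro on an aromatic carbon, and no measured compound yet carries bromo. The size of that step from compound 1 gives little reason to expect more than a small shift in this assay here, with no clear direction and probably nothing beyond the scatter.

The expected change is a 1.2-fold lower number from compound 2 to compound 3 (0.08 log units; within the scatter). For compound 3 the estimated value is 35000 nM, with an expected range of 15000 nM to 75000 nM.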

Compound 3, half-maximal inhibitory concentration: 48100 nM
Compound 3: middle estimate off by 1.4-fold (0.14 log units), on the low side, and the stated range covers the measured number.
By their numbers in this assay, from the lowest: compound 1; then compounds 2 and 3 (each within the scatter of the next).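

In this assay, this position, ortho to a methoxy group, shows no readable difference between the two halogens (the step is a 1.2-fold higher number from compound 2 to compound 3 (0.06 log units; within the scatter)). The gap to the nitro compound now appears with a second halogen (the step is a 2.6-fold higher number from compound 1 to compound 3 (0.42 log units; beyond the scatter)), so compound 1 stands apart from both compound 2 and compound 3, not from the chloro compound alone. Nothing measured here accounts for either step.

As far as these compounds go, whether fluoro, an amine, a carboxylic acid or a nitrile at this position would group with compound 1, with compounds 2 and 3, or with neither remains open. Also open, from the compounds shown here alone, is whether the gap between nitro and the halogens would persist with any change to the neighbouring methoxy group or elsewhere on the shared core.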